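Biphenyl ketone variant of a trimethoxyphenyl thiadiazine series

The compounds below may be only part of what the source reports. "The series", "measured", "known", "first", "only" and "open" are said of these compounds alone.

Compound 1: `COc1cc(-c2nnc3n2NC(c2cccs2)C(C(=O)c2ccc(C)cc2)S3)cc(OC)c1OC` — 5090 nM
Compound 2: `COc1cc(-c2nnc3n2NC(c2cccs2)C(C(=O)c2ccc(F)cc2)S3)cc(OC)c1OC` — 27400 nM
Compound 3: `COc1cc(-c2nnc3n2NC(c2ccco2)C(C(=O)c2ccc(C)cc2)S3)cc(OC)c1OC` — 7500 nM

Of the compounds shown here, three sharing one core have been tested in a functional assay on PC-3 cells (Homo sapiens) for cytotoxicity, read by MTT assay, with a stated time of 48 h; a lower number here means a stronger inhibitor, a higher number a weaker inhibitor. Compound 3 sits second highest of the three numbers; its nearest neighbour is compound 1, and the step of a 1.5-fold higher number from compound 1 to compound 3 (0.17 log units; within the scatter) lies within the scatter, so the two cannot be ranked. Compound 2 stands furthest from compound 3.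

The next compound, compound 4, is `COc1cc(-c2nnc3n2NC(c2ccco2)C(C(=O)c2ccc(-c4ccccc4)cc2)S3)cc(OC)c1OC`. It differs from compound 3 in one place: phenyl in place of methyl on an aromatic carbon. Going by the values given here, no measured step exchanges the methyl on that ring for a larger group. Among the compounds with values here, the only step at that position, a 5.4-fold higher number from compound 1 to compound 2 (0.73 log units; beyond the scatter), shows that a change there can move the number beyond the scatter. That step does not tell which way a phenyl would go, so the expectation for compound 4 rests on loose ground.

The estimate for compound 4 in this assay is therefore 9000 nM, with a range from 2500 nM to 35000 nM. This estimate corresponds to an expected step of a 1.2-fold higher number from compound 3 to compound 4 (0.08 log units; within the scatter).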

Compound 4, half-maximal inhibitory concentration: 45900 nM
The estimate for compound 4 lay 5.1-fold (0.71 log units) below the measured number; measured number outside the range, above it.
By their numbers in this assay, from the lowest: compounds 1 and 3 (each within the scatter of the next); then compounds 2 and 4 (each within the scatter of the next).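

In this assay, phenyl in place of methyl gives a 6.1-fold higher number from compound 3 to compound 4 (0.79 log units; beyond the scatter), so an added six-membered aromatic ring of carbon only at this position raises the number beyond the scatter. Alongside a 5.4-fold higher number from compound 1 to compound 2 (0.73 log units; beyond the scatter), this is a second replacement of the methyl that raises the number, here with furan-2-yl rather than thiophen-2-yl on the saturated ring carbon, and in both pairs the methyl compound has the lower number. No measurement at hand bears on why either replacement has this outcome.

The compounds shown leave open how a methoxy group, an amine or a carboxylic acid on that aromatic carbon would read. They also leave open whether phenyl would give a step of similar size with thiophen-2-yl on the saturated ring carbon.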